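Shifting a Methyl Group on Two Related Dopamine Ligands

The compounds below may be only part of what the source reports. "The series", "measured", "known", "first", "only" and "open" are said of these compounds alone.

Compound 1 `Cc1ccccc1CN1CCC(NC(=O)c2cccc3ccccc23)CC1` and compound 2 `Cc1cccc(CN2CCC(NC(=O)c3cccc4ccccc34)CC2)c1` share one core and differ only in the ring attached to the ring nitrogen through a saturated carbon. In an assay on isolated protein for displacement of a labelled ligand from D(4) dopamine receptor (Homo sapiens) (a higher number here means a weaker inhibitor, a lower number a stronger inhibitor), compound 1 gives 155 nM, and compound 2 gives 77 nM. The change between them, (3-methylphenyl in place of 2-methylphenyl on a saturated chain carbon bound to an amine nitrogen in a ring), made a 2.0-fold lower number from compound 1 to compound 2 (0.30 log units; within the scatter).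

Compound 3 `Cc1ccccc1CN1CCC(NC(=O)c2ccc3ccccc3c2)CC1` carries a different core; how the two cores differ is not broken down here. In this assay compound 3 gives 26 nM, the lowest number among the three measured compounds.

Compound 4 `Cc1cccc(CN2CCC(NC(=O)c3ccc4ccccc4c3)CC2)c1` has not yet been measured. It stands to compound 3 as compound 2 stands to compound 1, through the same change, (3-methylphenyl in place of 2-methylphenyl on a saturated chain carbon bound to an amine nitrogen in a ring). The expected step of a 1.7-fold lower number from compound 3 to compound 4 (0.24 log units; within the scatter) is small, resting on the one seen earlier, because a 2.0-fold lower number from compound 1 to compound 2 (0.30 log units; within the scatter). For compound 4 the estimate in this assay is 15 nM, with a likely range from 6 nM to 40 nM.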

Compound 4, inhibition constant: 11 nM
Estimate against measurement, compound 4: 1.4-fold (0.13 log units) above; the measured number falls inside the stated range.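

Putting 3-methylphenyl in place of 2-methylphenyl on the second core gave a 2.4-fold lower number from compound 3 to compound 4 (0.37 log units; beyond the scatter) in this assay. Set beside the earlier case, the change carried over from one core to the other at much the same size: the same change on two cores in this assay, a 2.0-fold lower number (0.30 log units; within the scatter) from compound 1 to compound 2 and a 2.4-fold lower number (0.37 log units; beyond the scatter) from compound 3 to compound 4, 1.2-fold (0.07 log units) apart, within the scatter of two such steps. Among the compounds shown here, this agreement rests on only two pairs of compounds, so it does not establish a rule for other cores, and the numbers alone do not explain why the two steps match.

The compounds shown leave open whether the same step would appear with a methoxy group or a chlorine atom in place of the methyl. They also leave open what an amine or a carboxylic acid on that ring would do.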